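A few compounds are considered here, and "the series" means these few. Any claim that something is new, unique, unknown or untested is made for them only; others in the source may bear on it.

Measured compounds:
- compound 1, `Fc1ccc(Cn2cc(CSC(=S)N3CCNCC3)nn2)cc1`, 32500 nM
- compound 2, `CC(C)(C)OC(=O)N1CCN(C(=S)SCc2cn(Cc3cc(=O)oc4cc(O)ccc34)nn2)CC1`, 4960 nM
- compound 3, `CC(C)(C)OC(=O)N1CCN(C(=S)SCc2cn(Cc3ccc(Cl)c(Cl)c3)nn2)CC1`, 33700 nM

In a functional assay on MGC-803 cells (Homo sapiens) for inhibition, read by MTT assay, with a stated time of 72 h (on this read-out lower numbers stand for stronger inhibition and higher numbers for weaker inhibition), compound 1 gives the second highest of the three numbers. Compound 3 gives a value within the scatter of compound 1, so the two cannot be told apart. Compound 2 gives a lower number, and that gap lies beyond the scatter.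

Compound 4, `Cc1ccc(Cn2cc(CSC(=S)N3CCNCC3)nn2)cc1`, has not yet been measured in this assay. Its difference from compound 1 is methyl in place of fluoro on an aromatic carbon. Among the measured compounds shown here, no step of this kind between measured compounds is available, so the size of the step is unknown; the expectation is a step from compound 1 to compound 4 of a 1.1-fold lower number from compound 1 to compound 4 (0.03 log units; within the scatter), which is none beyond the scatter. For compound 4 the expected value is 30000 nM, with a range from 12000 nM to 75000 nM.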

Compound 4, half-maximal inhibitory concentration: 64300 nM
For compound 4 the middle estimate is 2.1-fold (0.33 log units) below the measured one; the measured number falls inside the stated range.
By their numbers in this assay, from the lowest: compound 2; then compounds 1, 3 and 4 (each within the scatter of the next).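

In this assay the change from 4-fluorophenyl to 4-methylphenyl, on an aromatic carbon para to a large group, gives a 2.0-fold higher number from compound 1 to compound 4 (0.30 log units; within the scatter) and so does not separate the two groups. Among the compounds shown here, this is the first comparison in the set that differs in one place, and it shows that fluoro and methyl cannot be told apart at this position. Nothing available offers an explanation for this step. The compounds shown leave open how an amine, a methoxy group or a carboxylic acid would read at this position.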